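The source may hold more compounds than are shown below. What is called first, only, known or untested is meant among the compounds shown, and "the series" means these compounds.

Of the compounds shown here, three of a shared core have been measured in a functional assay on PC-3 cells (Homo sapiens) for antiproliferative activity, read by MTT assay, tested at 1 uM; on this read-out higher numbers stand for a stronger effect at the one concentration tested and lower numbers for a weaker effect. Compound 1 `COc1cc(C(=O)N/N=C/c2ccccc2C(F)(F)F)cc(OC)c1OC` gives 45%, compound 3 `COc1cc(C(=O)N/N=C/c2ccccc2F)cc(OC)c1OC` gives 70.6%, and compound 2 `COc1ccc(C2OC(c3cc(OC)c(OC)c(OC)c3)=NN2C(C)=O)c(OC)c1` gives 69.5%. On these numbers compound 2 stands second highest of three: its gap to compound 3 lies within the scatter, while its gap to compound 1 lies beyond it. Going by the values given here, the only step between two measured compounds that differ in one place is a number 25.6 percentage points higher from compound 1 to compound 3 (beyond the scatter), a fluoro in place of trifluoromethyl on an aromatic carbon.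

Compound 4 `COc1cc(C2=NN(C(C)=O)C(c3ccccc3F)O2)cc(OC)c1OC` has not been measured. It differs from compound 2 as follows: 2-fluorophenyl in place of 2,4-dimethoxyphenyl on a saturated ring carbon. The step from compound 1 to compound 3 changes a different group at a different place, so it gives no direct guide to this swap. The data do hold compound 3, whose aryl part is a 2-fluorophenyl, at a value close to that of compound 2. For compound 4 I therefore expect a step of about a number 5.5 percentage points lower from compound 2 to compound 4 (within the scatter), which is within the scatter. My estimate for compound 4 in this assay is 64%, with a range from 44% to 80%.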

Compound 4, a percentage reported as inhibition, at one concentration (the size of the read-out at that concentration, not a potency): 13.5%
For compound 4 the middle estimate is 50.5 percentage points above the measured one; the measured number lies below the stated range.
By their numbers in this assay, from the lowest: compound 4; then compound 1; then compounds 2 and 3 (each within the scatter of the next).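

In this assay, the saturated ring carbon of this core proves to be a highly sensitive place: 2-fluorophenyl in place of 2,4-dimethoxyphenyl gives a number 56 percentage points lower from compound 2 to compound 4 (beyond the scatter). Going by these compounds alone, no earlier pair of compounds changed anything at this carbon, so this is the first sign of how much the aryl group here can matter. The swap removes both methoxy groups and adds a fluorine in a single step, and no measurement at hand explains the drop.

On these data alone, it remains open whether the loss follows from losing the methoxy groups, gaining the fluorine, or both, and where a plain phenyl would fall relative to compound 2 and compound 4. As far as these compounds go, how a phenyl carrying an amine or a hydroxyl group would read at this carbon also remains open.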